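Swapping a Sulfur Tail for a Pyridine Ether

This account rests on a few compounds, and the source may have more. Where it says the series, first, only, none or still open, it means among the compounds named here.

Compound 1, `Cc1cc(CCOc2ccc(-c3c(C)nc(C)c([C@H](OC(C)(C)C)C(=O)O)c3N3CCC(C)(C)CC3)cc2)ccc1F`, gives >= 33500 nM in a toxicity assay on MT2 cells (Homo sapiens) for cytotoxicity, read by XTT assay, with a stated time of 4 days; a higher number here means that more compound is tolerated, a lower number that less compound is tolerated.
Compound 2, `Cc1nc(C)c([C@H](OC(C)(C)C)C(=O)O)c(N2CCC(C)(C)CC2)c1-c1ccc(SCCc2ccc(F)cc2)cc1`, gives >= 32000 nM in this assay.

Both of these values are limits of this assay rather than measured numbers: compound 1 sits at the limit noted in the limit of >= 33500 nM in this assay, at which 1 of the 2 values shown sits, and compound 2 sits at the limit noted in the limit of >= 32000 nM in this assay, at which 1 of the 2 values shown sits. Compound 2 therefore stands at a limit, with no number of its own. Among the compounds with values here, neither compound was toxic enough to the cells for a real value to appear, so the one measured step between them, a step that the two limits leave unreadable from compound 1 to compound 2, cannot be read in size or direction.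

Compound 3 is `Cc1nc(C)c([C@H](OC(C)(C)C)C(=O)O)c(N2CCC(C)(C)CC2)c1-c1ccc(OCCc2ccncc2)cc1`. It differs from compound 2 by the change (2-(pyridin-4-yl)ethoxy in place of (2-(4-fluorophenyl)ethyl)sulfanyl on an aromatic carbon). Within the data shown here, the only measured step that touches this part of the structure is the unreadable one from compound 1 to compound 2, so there is no basis for expecting a change beyond the scatter in this assay. Compound 3 is therefore expected to stay at the limit as well, with an estimated step that the limit leaves unreadable from compound 2 to compound 3. My estimate for compound 3 is 33000 nM, with a range from 18000 nM to 60000 nM.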

Compound 3, half-maximal cytotoxic concentration: >= 25000 nM
Compound 3: a limit, no number; the forecaster's own chance of this, stated with the estimate: 85%; the middle value does not contradict the limit.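

Compound 3 also gives a limit rather than a number: the limit of >= 25000 nM in this assay, at which 1 of the 3 values shown sits. Within the data shown here, with compound 1, compound 2 and compound 3 all at limits, no step among them can be read in size or direction. As far as these compounds go, what stays open is the actual half-maximal cytotoxic concentration of each compound, and whether 2-(pyridin-4-yl)ethoxy in place of (2-(4-fluorophenyl)ethyl)sulfanyl changes it at all.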